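Acetyl for methyl on the side-chain oxygen: compound 3

The compounds below may be only part of what the source reports. "The series", "measured", "known", "first", "only" and "open" are said of these compounds alone.

Measured compounds:
compound 1 `CCc1cccc2c(OC(C)=O)c(-c3occ(C)c3COC(C)=O)ccc12` — > 10 ug/mL
compound 2 `CCOc1c(-c2occ(C)c2COC)ccc2c(CC)cccc12` — > 10 ug/mL

In a functional assay on ZR-75-1 cells (Homo sapiens) for cytotoxicity, read by MTT assay, with a stated time of 72 h (on this read-out lower numbers stand for an effect already at smaller amounts and higher numbers for an effect only at larger amounts of compound), compound 1 gives > 10 ug/mL, which is a limit of the assay and not a number. Compound 2 likewise returns only a limit, > 10 ug/mL. Compound 2 therefore stands at the edge of the measured window, and the same holds for the rest of the series: the limit of > 10 ug/mL in this assay, at which 2 of the 2 values shown sit. Among the measured compounds shown here, no step between two measured compounds is available, so no size of effect for any structural change has been measured.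

The new compound, compound 3 `CCOc1c(-c2occ(C)c2COC(C)=O)ccc2c(CC)cccc12`, differs from compound 2 by acetyl in place of methyl on an oxygen on a saturated carbon. Compound 1 already carries the acetoxymethyl group, and its result gives no sign of a gain over the limit. On that basis the step in this assay is expected to be none beyond the scatter: a step that the limit leaves unreadable from compound 2 to compound 3. Compound 3 is expected around 15 ug/mL, with a range from 5 ug/mL to 45 ug/mL, and a limit rather than a number is the more likely report.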

Compound 3, concentration for half-maximal effect: 4.9 ug/mL
Compound 3: middle estimate off by 3.1-fold (0.49 log units), on the high side; measured number outside the range, below it.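

Compound 3 is the only compound shown that gives a number rather than a limit in this assay, and the change on the side chain alone separates it from compound 2: acetyl in place of methyl on an oxygen on a saturated carbon gives an at least 2.0-fold lower number from compound 2 to compound 3 (0.30 log units; that floor lies within the scatter). The acetoxymethyl group does not account for this result by itself, as compound 1 carries it and still stands at a limit; ethyl in place of acetyl on an oxygen on an aromatic ring gives an at least 2.0-fold lower number from compound 1 to compound 3 (0.30 log units; that floor lies within the scatter). Both steps are floors and not sizes, so neither change can yet be ranked against the other, and the series still sits mostly at the edge of the window: the limit of > 10 ug/mL in this assay, at which 2 of the 3 values shown sit.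

On these data alone, it remains open whether the acetyl itself matters on the side-chain oxygen, or whether a free hydroxyl, a propionyl or a benzoyl there would read the same. As far as these compounds go, it is also open whether a longer chain than ethyl, or a chain ending in an amine, on the oxygen on the aromatic ring would keep the number of compound 3 within the window.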